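A few compounds are considered here, and "the series" means these few. Any claim that something is new, unique, unknown or untested is made for them only; others in the source may bear on it.

Measured in an in vivo ADME assay on the whole organism (strain Sprague-Dawley) for pharmacokinetics, with Rattus norvegicus as the target, at a dose of 2 mg/kg by the intravenous route; on this read-out lower numbers stand for slow clearance and higher numbers for fast clearance:
Compound 1 `N#Cc1cc(Cl)cc(Oc2cc(OCc3noc4nc(-n5ccnc5)ccc34)ccc2Cl)c1`: 26.9 mL/min/kg
Compound 2 `N#Cc1cc(Cl)cc(Oc2cc(OCc3noc4nc(N)ccc34)ccc2Cl)c1`: 93.4 mL/min/kg
Compound 3 `N#Cc1cc(Cl)cc(Oc2cc(OCc3n[nH]c4nc(N)ccc34)cc(F)c2Cl)c1`: 10 mL/min/kg

Compound 2, at 93.4 mL/min/kg, holds the highest number of the three, with compound 1 nearest and compound 3 furthest. Compound 4 `CNc1ccc2c(COc3ccc(Cl)c(Oc4cc(Cl)cc(C#N)c4)c3)noc2n1` carries methyl in place of hydrogen on a nitrogen on an aromatic ring, which reads as amino to methylamino. Among the compounds with values here, only one measured step bears on this: a 3.5-fold higher number from compound 1 to compound 2 (0.54 log units; beyond the scatter), with amino in place of 1H-imidazol-1-yl on an aromatic carbon. Within the data shown here, compound 3 differs from compound 2 in more than one place and gives no step. Among the measured compounds shown here, no measured step covers a methyl entering on this nitrogen, so no change beyond the scatter is expected. The expected step is a 1.2-fold lower number from compound 2 to compound 4 (0.10 log units; within the scatter). For compound 4 the estimate is 75 mL/min/kg, with an expected range of 38 mL/min/kg to 135 mL/min/kg.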

Compound 4, clearance: 24.6 mL/min/kg
Beside the measured number, compound 4's estimate is 3.0-fold (0.48 log units) above it; measured number outside the range, below it.
By their numbers in this assay, from the lowest: compound 3; then compounds 4 and 1 (each within the scatter of the next); then compound 2.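

In this assay, a methyl in place of hydrogen on the nitrogen on the aromatic ring gives a 3.8-fold lower number from compound 2 to compound 4 (0.58 log units; beyond the scatter), so the smallest addition here already moves the read-out beyond the scatter. Methylamino in place of 1H-imidazol-1-yl gives a 1.1-fold lower number from compound 1 to compound 4 (0.04 log units; within the scatter), leaving compound 2 with its free amino group alone at the high end of this series. Nothing measured here accounts for the methyl step. On these data alone, whether dimethylamino or ethylamino would behave like methylamino remains open. So does whether the methyl step would carry over to the core of compound 3.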